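Cytotoxicity of cyclopentanediol acrylamides in insect cells

This account rests on a few compounds, and the source may have more. Where it says the series, first, only, none or still open, it means among the compounds named here.

Measured so far:
compound 1 `CCC[C@H]1C[C@@H](O)[C@@H](O)C1`: > 350000 nM
compound 2 `O=C(/C=C/[C@H]1C[C@@H](O)[C@@H](O)C1)Oc1ccccc1`: > 200000 nM
compound 3 `CN(C)C(=O)/C=C/[C@H]1C[C@@H](O)[C@@H](O)C1`: > 250000 nM

The three measured compounds share a diol-bearing core and differ in the side chain. Compound 1 `CCC[C@H]1C[C@@H](O)[C@@H](O)C1` carries a propyl chain, compound 2 `O=C(/C=C/[C@H]1C[C@@H](O)[C@@H](O)C1)Oc1ccccc1` a phenyl ester on the unsaturated linker, and compound 3 `CN(C)C(=O)/C=C/[C@H]1C[C@@H](O)[C@@H](O)C1` a dimethylamide on the same linker. In an ADME assay on S2 cells (Drosophila melanogaster) for cytotoxicity, read by MTT assay (on this read-out lower numbers stand for an effect already at smaller amounts and higher numbers for an effect only at larger amounts of compound), compound 1 gives > 350000 nM, which is a limit of the assay, not a number. In this assay compound 2 gives > 200000 nM, again only a limit. Compound 3 gives > 250000 nM in this assay, which is also a limit; compound 3 therefore stands with the others, all three sitting at limits the limit of > 200000 nM in this assay, at which 1 of the 3 values shown sits, the limit of > 250000 nM in this assay, at which 1 of the 3 values shown sits (the limit of > 350000 nM in this assay, at which 1 of the 3 values shown sits), and no order among them can be read from these values.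

Compound 4 `CCNC(=O)/C=C/[C@H]1C[C@@H](O)[C@@H](O)C1` has not yet been measured. It differs from compound 3 by ethylamino in place of dimethylamino on a carbonyl carbon. Among the measured compounds shown here, since every measured value here is a limit and no measured step exists, the step of a number no higher from compound 3 to compound 4 (the limit leaves the size open) is expected to be none beyond the scatter. Compound 4 is therefore expected to give about 250000 nM in this assay, within a range from 100000 nM to 600000 nM, and most likely the assay will again report only a limit.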

Compound 4, half-maximal effective concentration: > 250000 nM
Compound 4 gave a limit, no number; the forecaster's own chance of this, stated with the estimate: 85%; the middle value sits exactly at the limit.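

Compound 3 and compound 4 each give only a limit in this assay, so no step can be read between them: the limit of > 250000 nM in this assay, at which 2 of the 4 values shown sit.

The compounds shown leave open at what concentration any of them would affect these cells, and whether changing the side chain alters that concentration.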